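The source may report more compounds than this note shows. Statements on the series, on what has been measured and on what is new or still open speak of the compounds shown alone.

Compound 2 `Cc1cc(OCCCN2CCCC2=O)cc(C)c1-c1cccc(COc2ccc3c(c2)OC[C@H]3CC(=O)O)c1` shares its core with compound 1 `Cc1cc(OCCCS(C)(=O)=O)c(Cl)c(C)c1-c1cccc(COc2ccc3c(c2)OC[C@H]3CC(=O)O)c1`, and the two differ only in the chain that hangs from the aromatic oxygen and in a chlorine on that ring. In a functional assay on CHO cells for agonist activity at Free fatty acid receptor 1 (Homo sapiens), read by FLIPR and calcium flux, with a stated time of 90 s, in the presence of a further agent that is not named here (on this read-out higher numbers stand for an effect only at larger amounts of compound and lower numbers for an effect already at smaller amounts), compound 2 gives 17 nM. In this assay compound 1 gives 16 nM. Compound 2 thus holds the higher of the two numbers, but its gap to compound 1 lies within the scatter, so the two cannot be told apart on these measurements.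

Compound 3 `Cc1cc(OCC2(O)CCS(=O)(=O)CC2)cc(C)c1-c1cccc(COc2ccc3c(c2)OC[C@H]3CC(=O)O)c1` is not yet measured. It carries 4-hydroxy-1,1-dioxothian-4-yl in place of 2-(2-oxopyrrolidin-1-yl)ethyl on a saturated chain carbon bound to an oxygen on an aromatic ring. The chain is therefore exchanged for a ring that brings a hydroxyl and a cyclic sulfone, while the rest of the molecule is untouched. Since compound 1 and compound 2 sit close together despite carrying quite different chains at this oxygen, the step from compound 2 to compound 3 is expected to be small, most likely a modest move toward the weaker side, a 1.5-fold higher number from compound 2 to compound 3 (0.17 log units; within the scatter). Compound 3 is accordingly estimated at 25 nM in this assay, with a range from 8 nM to 80 nM.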

Compound 3, half-maximal effective concentration: 13 nM
Compound 3: middle estimate off by 1.9-fold (0.28 log units), on the high side; the measured number falls inside the stated range.
By their numbers in this assay, from the lowest: compounds 3, 1 and 2 (each within the scatter of the next).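

In this assay, the exchange of 2-(2-oxopyrrolidin-1-yl)ethyl for 4-hydroxy-1,1-dioxothian-4-yl on a saturated chain carbon bound to an oxygen on an aromatic ring gives a 1.3-fold lower number from compound 2 to compound 3 (0.12 log units; within the scatter) and so leaves the two compounds indistinguishable on these measurements. Compound 1 and compound 2 differ in two places, which left the contribution of the chain alone unresolved, whereas compound 2 and compound 3 differ only at this position. The result therefore shows directly that this position accommodates a change from a chain ending in a 2-oxopyrrolidin-1-yl group to a six-membered ring bearing a hydroxyl and a cyclic sulfone without a change in the number beyond the scatter, and no available evidence bears on why the number holds across this exchange.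

The compounds shown leave open whether the hydroxyl or the cyclic sulfone of compound 3 matters on its own, as the 1,1-dioxothian-4-yl ring without the hydroxyl or the 4-hydroxycyclohexyl ring without the sulfone would show. They also leave open whether this position would accept an amine or a carboxylic acid, since every group shown here carries no net charge.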